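Aryl triazole sulfonamides: tolerance on liver cells

This account rests on a few compounds, and the source may have more. Where it says the series, first, only, none or still open, it means among the compounds named here.

Measured compounds:
compound 1 `Cc1ccccc1-n1cc(-c2cccc(NS(=O)(=O)c3c[nH]c(=O)[nH]c3=O)c2)nn1`, 15300 nM
compound 2 `Cc1cccc(-n2cc(-c3ccc(NS(=O)(=O)c4c[nH]c(=O)[nH]c4=O)cc3)nn2)c1`, 39000 nM

In an ADME assay on L02 cells (Homo sapiens) for cytotoxicity, read by MTT assay, with a stated time of 24 h (a higher number here means that more compound is tolerated, a lower number that less compound is tolerated), compound 2 gives 39000 nM, the higher of the two numbers measured; its nearest neighbour, compound 1, gives 15300 nM in this assay, a lower number that lies beyond the usual scatter, so compound 2 is the better tolerated of the two.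

Compound 3 `O=c1[nH]cc(S(=O)(=O)Nc2ccc(-c3cn(-c4ccc(Cl)cc4)nn3)cc2)c(=O)[nH]1` differs from compound 2 in one place: 4-chlorophenyl in place of 3-methylphenyl on an aromatic nitrogen. Among the compounds with values here, no measured pair shows this exchange, so no step is known for it. Within the data shown here, with only two compounds measured, any expectation rests thinly, and the change in this assay from compound 2 to compound 3 is expected to be small, likely within the scatter, or a modest drop. Compound 3 is therefore estimated to give about 30000 nM in this assay, with a plausible range from 10000 nM to 90000 nM, a step of a 1.3-fold lower number from compound 2 to compound 3 (0.11 log units; within the scatter).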

Compound 3, half-maximal cytotoxic concentration: 42900 nM
The estimate for compound 3 lay 1.4-fold (0.16 log units) below the measured number; the range from low to high includes it.
By their numbers in this assay, from the lowest: compound 1; then compounds 2 and 3 (each within the scatter of the next).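

Within the data shown here, the exchange of 3-methylphenyl for 4-chlorophenyl on the aromatic nitrogen gives a 1.1-fold higher number from compound 2 to compound 3 (0.04 log units; within the scatter) in this assay, the first step that changes only one place. At this position, then, the two groups cannot be told apart in tolerance on these liver cells, although each is a six-membered aromatic ring of carbon only, so the step speaks only for this pair. Nothing on hand accounts for this result. The step also changes both the substituent and where it sits on the phenyl ring, so the compounds shown do not separate those two changes. They also leave open how this position would read with a group of another kind, such as an amine, a carboxylic acid or a longer chain.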